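Halogen swap at the aryl ether of the coumarin series

The source may report more compounds than this note shows. Statements on the series, on what has been measured and on what is new or still open speak of the compounds shown alone.

Measured compounds:
compound 1 `Cc1nn(C)c(Oc2ccc(F)cc2)c1/C=N\CCCCCOc1cc2oc(=O)cc(C)c2cc1Cl` – 22100 nM
compound 2 `Cc1nn(C)c(Oc2ccc(Br)cc2)c1/C=N\CCCCCOc1cc2oc(=O)cc(C)c2cc1Cl` – "not determined" (no result reported)

In a functional assay on SMMC-7721 cells (Homo sapiens) for antiproliferative activity, read by MTT assay, with a stated time of 72 h (a lower number here means a stronger inhibitor, a higher number a weaker inhibitor), compound 1 gives 22100 nM. For compound 2 this assay returns "not determined" (no result reported), so compound 2 stands on no number at all; the only figure available for the series is the value of compound 1, and nothing can be said of how compound 2 compares with it.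

Compound 3 `Cc1nn(C)c(Oc2ccc(I)cc2)c1/C=N\CCCCCOc1cc2oc(=O)cc(C)c2cc1Cl` has not yet been measured. The change from compound 2 to compound 3 is iodo in place of bromo on an aromatic carbon, read one bond further out as 4-bromophenoxy to 4-iodophenoxy. For the measured compounds named here, no step between measured compounds shows what such a halogen swap does in this assay; with compound 2 lacking a value, there is no anchor for its size or direction, and an effect no larger than the usual scatter is the working assumption.

Going by the values given here, compound 3 is therefore expected to land near the only measured value of the series, around 20000 nM, with a range of 6000 nM to 65000 nM.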

Compound 3, half-maximal inhibitory concentration: > 25000 nM
Compound 3 was reported as a limit; the forecaster's own chance of this, stated with the estimate: 25%; at least 1.2-fold (0.09 log units) between middle value and limit.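

In this assay compound 3, which carries 4-iodophenoxy, is reported only as a limit, > 25000 nM, a limit of the assay and not a number. For the compounds shown here, this gives the first readable step at this aromatic carbon, iodo in place of fluoro, as an at least 1.1-fold higher number from compound 1 to compound 3 (0.05 log units; that floor lies within the scatter); the step has a floor and no measured size, so it establishes no order between the fluoro and iodo compounds and does not exclude a larger difference. The series also now shows where its readings stop, and the one reading at that limit is that of compound 3: the limit of > 25000 nM in this assay, at which 1 of the 3 values shown sits.

On these data alone, the step from compound 2 to compound 3 cannot be read: compound 2 carries no number, and the size and direction of the change from bromo to iodo stay open. Also open, as far as these compounds go, are how far the true value of compound 3 lies past its limit and what a group other than a halogen, such as an amine, a carboxylic acid or a methoxy group, would do on this aromatic carbon.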